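The source may hold more compounds than are shown below. What is called first, only, known or untested is meant among the compounds shown, and "the series" means these compounds.

Compound 3, `CN1CCN(c2ccc(Nc3nc(-c4cccc(NC(=O)c5ccc(C(C)(C)C)cc5)c4)sc3C(N)=O)cc2)CC1`, was examined in a functional assay on Ramos cells (Homo sapiens) for antiproliferative activity, read by CCK-8 assay, with a stated time of 72 h; on this read-out higher numbers stand for weaker inhibition and lower numbers for stronger inhibition. In this assay compound 3 gives 8600 nM. For the measured compounds named here, compound 2, `CN1CCN(c2ccc(Nc3nc(-c4cccc(NC(=O)c5ccccc5F)c4)sc3C(=O)O)cc2)CC1`, was run in the same test, and in this assay compound 2 gives 6300 nM, a number that lies within the usual scatter of the one found for compound 3. Compound 1, `CCOC(=O)c1sc(-c2cccc(NC(=O)c3ccc(C(C)(C)C)cc3)c2)nc1Nc1ccc(N2CCN(C)CC2)cc1`, carries an ester in place of the acid or the primary amide on the shared core; in this assay compound 1 gives "not determined" (no result reported), meaning that no result was reported for it, so the two numbers from compound 2 and compound 3 are all the measured ground available.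

Compound 4, `CN1CCN(c2ccc(Nc3nc(-c4cccc(NC(=O)c5ccccc5F)c4)sc3C(N)=O)cc2)CC1`, has not yet been measured. It keeps the primary amide of compound 3 and differs from it in one place: 2-fluorophenyl in place of 4-(tert-butyl)phenyl on a carbonyl carbon. Going by the values given here, no measured pair shows this exchange on its own, so nothing firm can be said about its size or direction; the expectation is that the step from compound 3 to compound 4 stays within the scatter, a 1.3-fold lower number from compound 3 to compound 4 (0.12 log units; within the scatter). Compound 4 is therefore estimated at 6500 nM, with a range from 2000 nM to 25000 nM.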

Compound 4, half-maximal inhibitory concentration: 1360 nM
Compound 4: the middle estimate sits 4.8-fold (0.68 log units) above what was measured; measured number outside the range, below it.
By their numbers in this assay, from the lowest: compound 4; then compounds 2 and 3 (each within the scatter of the next).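

In this assay, 2-fluorophenyl in place of 4-(tert-butyl)phenyl on a carbonyl carbon, with the primary amide kept, gives a 6.3-fold lower number from compound 3 to compound 4 (0.80 log units; beyond the scatter), so the group at this position clearly affects the number. With 2-fluorophenyl held fixed, amino in place of hydroxy on the other carbonyl carbon gives a 4.6-fold lower number from compound 2 to compound 4 (0.67 log units; beyond the scatter), showing that the primary amide reads better here than the carboxylic acid. The data at hand offer no explanation for either step.

From the compounds shown here alone, it remains open whether the first step follows from the arrival of the fluorine or the departure of the tert-butyl, which a plain phenyl or a 4-fluorophenyl group on that carbonyl carbon could help to separate. Also open, going by these compounds, is how an N-methyl amide or a nitrile would compare with the primary amide.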